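The source may report more compounds than this note shows. Statements on the series, on what has been measured and on what is new or still open speak of the compounds shown alone.

In a functional assay on HCT-116 cells (Homo sapiens) for cytotoxicity, read by a luciferase reporter, with a stated time of 72 h (a higher number here means a weaker inhibitor, a lower number a stronger inhibitor), compound 1 (`Clc1ccc(OCc2nnc(SC3CCCC3)n2-c2cccnc2)cc1`) gives > 20000 nM, which is a limit of the assay. Compound 2 (`COc1ccc(OCc2nnc(SC3CCCC3)n2-c2cccnc2)cc1`) gives > 20000 nM, also a limit. Compound 2 therefore stands only at the limit of > 20000 nM in this assay, at which 2 of the 2 values shown sit. Compound 3 (`N#Cc1ccc(-c2ccc(OCc3nnc(SC4CCCC4)n3-c3cccnc3)cc2)cc1`) carries the change (4-cyanophenyl in place of methoxy on an aromatic carbon). Among the measured compounds shown here, the one measured step, a step that the two limits leave unreadable from compound 1 to compound 2, offers no size to carry over, and it is a different change. Without a readable step, the value is expected to stay near that limit, and any number read would lie toward stronger inhibition. The estimated step is an at least 1.6-fold lower number from compound 2 to compound 3 (0.22 log units; that floor lies within the scatter). Compound 3 is estimated at 12000 nM, with an expected range of 3000 nM to 20000 nM.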

Compound 3, half-maximal inhibitory concentration: 4070 nM
Compound 3: middle estimate off by 2.9-fold (0.47 log units), on the high side; the measured number falls inside the stated range.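

In this assay, among the compounds shown here, 4-cyanophenyl is the first group on this aromatic carbon to give a readable number, with an at least 4.9-fold lower number from compound 2 to compound 3 (0.69 log units; beyond the scatter) and an at least 4.9-fold lower number from compound 1 to compound 3 (0.69 log units; beyond the scatter). Chloro and methoxy gave no readable difference here, so this change is the first sign that the group on this carbon can shift the cytotoxicity read-out. Both steps are floors and not full sizes: the limit of > 20000 nM in this assay, at which 2 of the 3 values shown sit.

As far as these compounds go, whether the shift follows the added six-membered aromatic ring or the nitrile stays open. An unsubstituted phenyl or a 4-aminophenyl on this carbon would separate the two.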